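Selenium Comes Back, Now Bearing a Benzyl Group

The source may report more compounds than this note shows. Statements on the series, on what has been measured and on what is new or still open speak of the compounds shown alone.

Compound 1 `C[Se]/C(=N\C(=O)c1ccco1)NC(=O)c1ccco1` is the strongest of the measured set: in a functional assay on HT-29 cells (Homo sapiens) for cytotoxicity, read by MTT assay, with a stated time of 72 h (on this read-out higher numbers stand for weaker inhibition of growth and lower numbers for stronger inhibition of growth), compound 1 gives 0.05 nM. Compound 2 `C[Se]/C(=N\C(=O)c1cnc2ccccc2c1)NC(=O)c1cnc2ccccc2c1` shares the selenium but carries a different aromatic amide on each side, and in this assay compound 2 gives 200 nM. Compound 3 `CS/C(=N\C(=O)c1cnc2ccccc2c1)NC(=O)c1cnc2ccccc2c1` is the sulfur counterpart of compound 2. In this assay compound 3 reaches only the limit > 100000 nM, which is a boundary of the measurement rather than a number, as noted for (the limit of > 100000 nM in this assay, at which 1 of the 3 values shown sits). Among the compounds with values here, the single measured step that touches this pair is an at least 500-fold higher number from compound 2 to compound 3 (2.69 log units; beyond the scatter).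

Compound 4 `O=C(/N=C(/NC(=O)c1cnc2ccccc2c1)[Se]Cc1ccccc1)c1cnc2ccccc2c1` is not yet measured. It differs from compound 3 by a group of 8 heavy atoms (7 carbon, 1 selenium; one six-membered aromatic ring of carbon only) in place of a group of 2 heavy atoms (1 carbon, 1 sulfur; no ring), on a carbon with a double bond to nitrogen. Within the data shown here, since that change restores selenium, the step of an at least 500-fold higher number from compound 2 to compound 3 (2.69 log units; beyond the scatter) is the relevant evidence, and it is expected to run largely in reverse, while the benzyl part has no measured precedent here. The step from compound 3 to compound 4 is therefore expected to be an at least 200-fold lower number from compound 3 to compound 4 (2.30 log units; beyond the scatter). Compound 4 is estimated at 500 nM, within a range from 50 nM to 10000 nM.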

Compound 4, concentration for 50% growth inhibition: 26100 nM
The estimate for compound 4 lay 52-fold (1.72 log units) below the measured number, outside the stated range (above it).
By their numbers in this assay, from the lowest: compound 1; then compound 2; then compound 4. At a limit, above all of these: compound 3.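

In this assay, the selenium atom is not enough on its own for strong growth inhibition, since phenyl in place of hydrogen on the saturated chain carbon bound to selenium gives a 130-fold higher number from compound 2 to compound 4 (2.12 log units; beyond the scatter). So the group attached to selenium also matters at this position, and benzyl on selenium is far less favourable here than methyl on selenium. Exchanging methylsulfanyl for the benzyl-bearing selenium group still gives an at least 3.8-fold lower number from compound 3 to compound 4 (0.58 log units; beyond the scatter), but the true size of this step is unknown, as the value for compound 3 is a limit rather than a number: the limit of > 100000 nM in this assay, at which 1 of the 4 values shown sits.

These compounds leave open whether the loss needs the phenyl ring itself or would also follow from a longer chain on selenium, such as ethyl or propyl. They also leave open how a benzyl group on sulfur would behave, and whether benzyl on selenium would cost as much on the core of compound 1.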